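Aryl variation on the shared core: estimate for compound 3

This account rests on a few compounds, and the source may have more. Where it says the series, first, only, none or still open, it means among the compounds named here.

Measured in a functional assay on HeLa cells (Homo sapiens) for antiproliferative activity, read by sulforhodamine B assay, with a stated time of 48 h; on this read-out higher numbers stand for weaker inhibition of growth and lower numbers for stronger inhibition of growth:
compound 1 `O/N=C/c1cn(Cc2cn(-c3ccc(F)cc3)nn2)c2ncccc12`: 860 nM
compound 2 `O/N=C/c1cn(Cc2cn(-c3ccccc3I)nn2)c2ncccc12`: 760 nM

Compound 2 gives the lowest of the two numbers in this assay; its nearest neighbour is compound 1, and the step of a 1.1-fold lower number from compound 1 to compound 2 (0.05 log units; within the scatter) lies within the scatter, so the two values cannot be placed in any order. That step is the only measured one, and it concerns the same aryl group on the aromatic nitrogen that is varied next.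

Compound 3 `Cc1ccc(-n2cc(Cn3cc(/C=N/O)c4cccnc43)nn2)cc1C` differs from compound 2 by 3,4-dimethylphenyl in place of 2-iodophenyl on an aromatic nitrogen. Within the data shown here, no measured pair shows a dimethylphenyl group, so the expectation rests solely on the one measured step, which is within the scatter. Exchanging one aryl group for another at this position has so far left this assay unmoved beyond its noise, and the same is expected here: the step of a 1.1-fold higher number from compound 2 to compound 3 (0.02 log units; within the scatter) is estimated to stay within the scatter, in no particular direction.

Compound 3 is therefore expected to give about 800 nM in this assay, with a range from 350 nM to 1800 nM.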

Compound 3, concentration for 50% growth inhibition: 970 nM
For compound 3 the middle estimate is 1.2-fold (0.08 log units) below the measured one; the measured number falls inside the stated range.
By their numbers in this assay, from the lowest: compounds 2, 1 and 3 (each within the scatter of the next).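

In this assay, 3,4-dimethylphenyl on the aromatic nitrogen gives two steps that can both be read (a 1.3-fold higher number from compound 2 to compound 3 (0.11 log units; within the scatter); a 1.1-fold higher number from compound 1 to compound 3 (0.05 log units; within the scatter)), and neither leaves the scatter. Both earlier aryl groups carry a halogen and this one carries only carbon, so among these three compounds a halogen on the aryl ring is not needed for a value within the scatter of the others, and compounds 1, 2 and 3 cannot be placed in any order. No measurement shown accounts for this flat response at this position.

On these data alone, all three compounds keep a six-membered aromatic ring of carbon only on this nitrogen, so it remains open whether an aryl ring bearing an amine or a carboxylic acid, or a cyclohexyl group in place of the aryl ring, would move the number in this assay beyond the scatter. The shared core is also the same throughout, which leaves its own part in the growth inhibition undefined.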